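Cyclohexyl for 4-chlorophenyl on the fused core: expected potency

The source may hold more compounds than are shown below. What is called first, only, known or untested is meant among the compounds shown, and "the series" means these compounds.

Measured in a functional assay on cells for antagonist activity at prostaglandin E2 receptor EP1 subtype (Rattus norvegicus), read by fluorescence and calcium flux, with a stated time of 60 s; a lower number here means a stronger inhibitor, a higher number a weaker inhibitor:
compound 1 `O=C(O)c1cccc(Cc2c(-c3ccccc3)nn3ccccc23)n1`: 2300 nM
compound 2 `O=C(O)c1cccc(Cc2c(-c3ccccc3)nn3cc(F)ccc23)n1`: 380 nM
compound 3 `O=C(O)c1cccc(Cc2c(-c3ccc(Cl)cc3)nn3cc(Cl)ccc23)n1`: 1100 nM

Compound 3 sits second highest of the three numbers: compound 1 gives a higher number, compound 2 a lower one. Compound 4 `O=C(O)c1cccc(Cc2c(C3CCCCC3)nn3cc(Cl)ccc23)n1` differs from compound 3 in one place: cyclohexyl in place of 4-chlorophenyl on an aromatic carbon. Within the data shown here, the only measured step, a 6.1-fold lower number from compound 1 to compound 2 (0.78 log units; beyond the scatter), concerns a fluoro on the fused system and does not touch the group exchanged here, so no measured step bears directly on this change. The direction is therefore open; a step of modest size either way, or none beyond the scatter, would be expected. Compound 4 is estimated at 2000 nM, within 500 nM to 8000 nM, which means an expected step of a 1.8-fold higher number from compound 3 to compound 4 (0.26 log units; within the scatter).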

Compound 4, half-maximal inhibitory concentration: 1200 nM
Compound 4: the middle estimate sits 1.7-fold (0.22 log units) above what was measured; the measured number falls inside the stated range.
By their numbers in this assay, from the lowest: compound 2; then compounds 3, 4 and 1 (each within the scatter of the next, the first and the last beyond it).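

In this assay, cyclohexyl in place of 4-chlorophenyl gives a 1.1-fold higher number from compound 3 to compound 4 (0.04 log units; within the scatter). In this pair, the aromatic ring at this position can therefore give way to a non-aromatic ring of carbon, with the chlorine lost, without a step beyond the scatter. Nothing available explains this result.

Open, as far as these compounds go, is whether the exchange behaves the same way on the fluoro core of compound 2. Also open, from the compounds shown here alone, is what a methyl group, or a six-membered ring carrying an amine, would do at this position.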